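Methoxy in place of chloro: an expected step down

A few compounds are considered here, and "the series" means these few. Any claim that something is new, unique, unknown or untested is made for them only; others in the source may bear on it.

In a physicochemical assay for lipophilicity (on this read-out lower numbers stand for lower lipophilicity and higher numbers for higher lipophilicity), compound 2 `COc1c(OC)c(OC(=O)C(C)(C)C)c2c(Cl)cccc2c1OC(=O)C(C)(C)C` gives 6.1, the highest of the three numbers. Compound 1 `COc1c(OC)c(OC(=O)C(C)(C)C)c2ccccc2c1OC(=O)C(C)(C)C` gives 5.69, and compound 3 `COc1c(OC)c(OC(C)=O)c2c(OC)cccc2c1OC(C)=O` gives 2.43, the lowest. Compound 4 `COc1c(OC)c(OC(=O)C(C)(C)C)c2c(OC)cccc2c1OC(=O)C(C)(C)C` departs from compound 2 at one place: methoxy in place of chloro on an aromatic carbon. For the measured compounds named here, the one measured step bearing on this is a number 0.41 log units higher from compound 1 to compound 2 (beyond the scatter), for chloro in place of hydrogen. Going by the values given here, no measured step shows methoxy entering alone. Losing the chloro is expected to undo a step of similar size, so the number in this assay should drop, estimated as a number 0.50 log units lower from compound 2 to compound 4 (beyond the scatter). For compound 4 the estimate is 5.6, with an expected range from 5.2 to 6.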

Compound 4, partition coefficient: 5.6
Estimate against measurement, compound 4: no gap at the digits printed; low and high end bracket the measured number.
By their numbers in this assay, from the lowest: compound 3; then compounds 4 and 1 (each within the scatter of the next); then compound 2.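

In this assay methoxy in place of chloro on an aromatic carbon gives a number 0.50 log units lower from compound 2 to compound 4 (beyond the scatter) at this place on the shared core. Methoxy in place of hydrogen gives a number 0.09 log units lower from compound 1 to compound 4 (within the scatter) at the same place, so methoxy and hydrogen cannot be told apart here, and of the three groups only chloro separates from the others beyond the scatter.

Going by these compounds, whether an amine, a carboxylic acid or a longer chain at this place would also stay with hydrogen and methoxy on this assay remains open. No measured evidence on why these groups read as they do is at hand.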